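Azetidinone series: nitro for chloro in this assay

This account rests on a few compounds, and the source may have more. Where it says the series, first, only, none or still open, it means among the compounds named here.

Compound 2 `CCOC(=O)/C(=C/c1ccccc1)CN1C(=O)[C@@H](OC)[C@H]1c1ccc(Cl)cc1` is the parent of this step. In an ADME assay on cells (Epithelial cell, Homo sapiens) for antiproliferative activity, read by MTT assay, with a stated time of 48 h (a lower number here means a stronger inhibitor, a higher number a weaker inhibitor), compound 2 returns "not toxic" (no number reported), an entry without a single number, so its standing cannot be ranked against a measured value. Within the data shown here, the only numerical reading in the set comes from compound 1 `COC(=O)/C(=C/c1ccccc1)CN1C(=O)[C@@H](OC)[C@H]1c1ccc(Cl)cc1`, which in this assay gives 37900 nM, a weak result. Like compound 2, compound 3 `COC(=O)/C(=C/c1ccccc1)CN1C(=O)[C@@H](OC)[C@H]1c1ccccc1C(F)(F)F` returns "not toxic" (no number reported) in this assay, a second entry without a single number. Nothing among these three values points to any compound as strong in this assay.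

Compound 4 `CCOC(=O)/C(=C/c1ccccc1)CN1C(=O)[C@@H](OC)[C@H]1c1cccc([N+](=O)[O-])c1` has not been measured. It differs from compound 2 by 3-nitrophenyl in place of 4-chlorophenyl on a saturated ring carbon. Among the measured compounds shown here, no step between two measured compounds exists for this change, so its size cannot be read from data. Given that compound 2 gives "not toxic" (no number reported) and compound 1 gives 37900 nM in this assay, the whole set sits at the weak end, and the step to compound 4 is expected to stay within the scatter or, if anything, to leave the reading weak. The value expected for compound 4 in this assay is 40000 nM, estimated to lie between 15000 nM and 120000 nM, with a real chance that again only a label and no number is returned.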

Compound 4, half-maximal inhibitory concentration: "not toxic" (no number reported)
No number was reported for compound 4; there is nothing to compare the estimate with.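

In this assay, among these compounds, compound 2 gives "not toxic" (no number reported) and compound 4 gives "not toxic" (no number reported) and neither entry is a number, so no step between compound 2 and compound 4 can be read. No evidence bears on this result. What the compounds shown leave open is how far 3-nitrophenyl in place of 4-chlorophenyl shifts the reading in numbers.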